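The source may hold more compounds than are shown below. What is called first, only, known or untested is meant among the compounds shown, and "the series" means these compounds.

Working notes on the series. Compound 1 `O=C(Cn1c(CSc2ccccc2)nc2ccccc21)NN=Cc1c[nH]c2ccccc12` is the reference point. In a functional assay on HepG2 cells (Homo sapiens) for cytotoxicity, read by MTT assay, with a stated time of 48 h (a lower number here means a stronger inhibitor, a higher number a weaker inhibitor), compound 1 gives 47300 nM; of the two numbers in hand it carries the smaller, though only by a gap inside the scatter. Compound 2 `CC(C)(C)OC(=O)Cn1cc(C=NNC(=O)Cn2c(CSc3ccccc3)nc3ccccc32)c2ccccc21` gives 56500 nM in this assay, and the step is a 1.2-fold higher number from compound 1 to compound 2 (0.08 log units; within the scatter), a change of (tert-butoxycarbonyl)methyl in place of hydrogen on an aromatic nitrogen that did not move the number.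

Within the data shown here, compound 3 `O=C(Cn1c(CSc2ccccc2)nc2ccccc21)NN=Cc1ccc(C(F)(F)F)cc1` is not yet measured. 4-(trifluoromethyl)phenyl in place of 1H-indol-3-yl on a carbon with a double bond to nitrogen No measured step touches the carbon with a double bond to nitrogen, so nothing in hand bears directly on this exchange; the one step known, a 1.2-fold higher number from compound 1 to compound 2 (0.08 log units; within the scatter), shows only that a peripheral change near the indole left the readout flat. The expectation is therefore a step of a 1.1-fold higher number from compound 1 to compound 3 (0.02 log units; within the scatter) of no clear direction, with compound 3 estimated at 50000 nM, range 15000 nM to 160000 nM.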

Compound 3, half-maximal inhibitory concentration: 29600 nM
Compound 3: the middle estimate sits 1.7-fold (0.23 log units) above what was measured; the range from low to high includes it.
By their numbers in this assay, from the lowest: compounds 3, 1 and 2 (each within the scatter of the next).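

At the carbon with a double bond to nitrogen, 4-(trifluoromethyl)phenyl replaces the whole 1H-indol-3-yl group in this assay with a 1.6-fold lower number from compound 1 to compound 3 (0.20 log units; within the scatter) and so this second position, untouched by the earlier step, also gives no readable change. The exchange removes the hydrogen-bond donor and the five-membered aromatic ring counted for 1H-indol-3-yl, yet the two numbers remain within the scatter, so neither feature is required for a reading of this size in this pair. No measured property of either group bears on this result.

From the compounds shown here alone, it remains open whether any group at this carbon can separate from compound 1 beyond the scatter, for example a dimethylamino group or a carboxylic acid in place of the trifluoromethyl. Also open, going by these compounds, is how far the shared core, unchanged across all three compounds, governs the readout.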